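A few compounds are considered here, and "the series" means these few. Any claim that something is new, unique, unknown or untested is made for them only; others in the source may bear on it.

Of the compounds shown here, two that share one core have been tested in a functional assay on WI-38 VA13 cells (Homo sapiens) for cytotoxicity; on this read-out higher numbers stand for an effect only at larger amounts of compound and lower numbers for an effect already at smaller amounts. Compound 1 `COCc1ccccc1C(=O)c1oc2cc(-c3ccccc3)cc(O)c2c1C` gives 0.1 ug/mL in this assay, and compound 2 `Cc1c(C(=O)c2ccc(F)c(F)c2)oc2cc(-c3ccccc3)cc(O)c12` gives 0.4 ug/mL. Among the measured compounds shown here, the single measured step, a 4.0-fold higher number from compound 1 to compound 2 (0.60 log units; beyond the scatter), exchanges the group on the carbonyl carbon. For the measured compounds named here, compound 2 therefore stands at the highest of the two numbers, with compound 1 as its only neighbour, a difference beyond the scatter.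

Compound 3 `Cc1c(C(=O)CCc2ccccc2)oc2cc(-c3ccccc3)cc(O)c12` has not yet been measured. It differs from compound 2 in one place: phenethyl in place of 3,4-difluorophenyl on a carbonyl carbon. Going by the values given here, the only step that bears on this change is a 4.0-fold higher number from compound 1 to compound 2 (0.60 log units; beyond the scatter), which shows that exchanging the group on the carbonyl carbon can move the number beyond the scatter. Compound 3 places a chain rather than a ring on that carbon, a larger alteration, so a step in this assay beyond the scatter is expected, though its direction is uncertain. The estimate for compound 3 is 0.6 ug/mL, within 0.1 ug/mL to 3 ug/mL. This corresponds to an expected step of a 1.5-fold higher number from compound 2 to compound 3 (0.18 log units; within the scatter).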

Compound 3, half-maximal effective concentration: > 4 ug/mL
Compound 3 was reported as a limit; the forecaster's own chance of this, stated with the estimate: 10%; middle value at least 6.6-fold (0.82 log units) from the limit.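

In this assay compound 3 is reported only as a limit, > 4 ug/mL. Phenethyl and 3,4-difluorophenyl have the same count of heavy atoms and each holds one six-membered aromatic ring of carbon only, yet moving that ring out onto a chain on the carbonyl carbon gives an at least 10-fold higher number from compound 2 to compound 3 (1.00 log units; beyond the scatter), and the comparison with the other ring-bearing compound gives an at least 40-fold higher number from compound 1 to compound 3 (1.60 log units; beyond the scatter), so this position tolerates far larger shifts than the step between the two directly attached rings had shown. How far the true number lies past this point cannot be read, and both steps are minimum sizes only: the limit of > 4 ug/mL in this assay, at which 1 of the 3 values shown sits.

The compounds shown leave open whether the chain or the loss of the two fluorines drives the shift, a question that a plain phenyl on the carbonyl carbon would help to settle. From the compounds shown here alone, whether benzyl, with its shorter chain, or a longer chain would behave like phenethyl also remains open.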